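This account rests on a few compounds, and the source may have more. Where it says the series, first, only, none or still open, it means among the compounds named here.

Measured compounds:
compound 1, `COc1ccc(-c2nc(SCC(=O)c3sc(-c4ccccc4)nc3C)[nH]c(=O)c2C#N)cc1`, 90.4%
compound 2, `Cc1nc(-c2ccc(Cl)cc2)sc1C(=O)CSc1nc(-c2cccc(Cl)c2)c(C#N)c(=O)[nH]1`, 95.2%

Both compounds were examined in a functional assay on U-87MG ATCC cells for antiproliferative activity against U-87 MG (Homo sapiens), read by MTT assay, with a stated time of 48 h, tested at 10 uM; on this read-out higher numbers stand for a weaker effect at the one concentration tested and lower numbers for a stronger effect. In this assay compound 1 gives 90.4%, and compound 2 gives 95.2%. The larger of the two numbers belongs to compound 2, but its nearest neighbour, compound 1, lies within the scatter of it, so the two cannot be told apart on these data. Within the data shown here, no pair of measured compounds differs in a single place, so no measured step is available to guide the next comparison.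

Compound 3, `Cc1nc(-c2ccccc2)sc1C(=O)CSc1nc(-c2cccc(Cl)c2)c(C#N)c(=O)[nH]1`, differs from compound 2 in one way: hydrogen in place of chloro on an aromatic carbon. The change is small, it brings in no ring and no donor or acceptor, and compound 1, which also carries an unsubstituted phenyl on its thiazole, sits close to compound 2 in this assay. The step from compound 2 to compound 3 is therefore expected to be a number 3.2 percentage points lower from compound 2 to compound 3 (within the scatter), that is, nothing beyond the scatter. For compound 3 in this assay the estimate is 92%, with a likely range from 80% to 101%.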

Compound 3, a percentage reported as activity, at one concentration (the size of the read-out at that concentration, not a potency): 83.7%
Estimate against measurement, compound 3: 8.3 percentage points above; measured number inside the range.
By their numbers in this assay, from the lowest: compounds 3, 1 and 2 (each within the scatter of the next, the first and the last beyond it).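

In this assay, taking the chloro away from an aromatic carbon para to a large group, so that 4-chlorophenyl becomes phenyl, gives a number 11.5 percentage points lower from compound 2 to compound 3 (beyond the scatter) and so a modestly stronger effect at the one concentration tested, which shows that this position does register on the read-out. The exchange of 3-chlorophenyl in place of 4-methoxyphenyl gives a number 6.7 percentage points lower from compound 1 to compound 3 (within the scatter) and so cannot be told from no change, which means compound 3 is separated from compound 2 but not from compound 1. Nothing shown here accounts for the size of either step.

A single step at this position leaves open whether other groups there, such as a methoxy group, an amine or a carboxylic acid, would move the number further in either direction, or whether hydrogen is the better choice. From the compounds shown here alone, it also remains open whether the chloro-to-hydrogen change would give a similar step with 4-methoxyphenyl in place of 3-chlorophenyl on the rest of the molecule.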